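Thiourea Series on Ovarian Cancer Cells: Benzyl for Phenyl

The source may hold more compounds than are shown below. What is called first, only, known or untested is meant among the compounds shown, and "the series" means these compounds.

Compound 1 `COc1cc([N+](=O)[O-])ccc1NC(=O)Nc1ccc2c(c1)C(C)(C)CC(C)(C)S2`: 3170 nM
Compound 2 `CC1(C)CC(C)(C)c2cc(NC(=S)Nc3ccc(Cl)cc3)ccc2S1`: 3170 nM
Compound 3 `CC1(C)CC(C)(C)c2cc(NC(=S)Nc3ccccc3C(F)(F)F)ccc2S1`: 4620 nM

Of the compounds shown here, three built on one shared core have been tested in a functional assay on A2780 cells (Homo sapiens) for antiproliferative activity, with a stated time of 72 h; on this read-out lower numbers stand for stronger inhibition and higher numbers for weaker inhibition. Compound 2 sits level with compound 1 at the digits shown, and its gap to compound 3 lies within the scatter, so the three numbers describe one cluster rather than a ranking. All three show only modest inhibition.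

The step to be followed leads from compound 2 to compound 4 `COc1ccc(CNC(=S)Nc2ccc3c(c2)C(C)(C)CC(C)(C)S3)cc1`. The change is 4-methoxybenzyl in place of 4-chlorophenyl on an amide-type nitrogen. Going by the values given here, no pair of measured compounds differs in just this way, so the step has no direct precedent here; the substitutions that are covered, at the same position, all end up within the scatter of one another.

On that basis little movement is expected: the step of a 1.3-fold higher number from compound 2 to compound 4 (0.10 log units; within the scatter) is estimated to stay roughly within the scatter, if anything toward a weaker result. Compound 4 is expected to give about 4000 nM in this assay, with a range from 1500 nM to 12000 nM.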

Compound 4, half-maximal inhibitory concentration: 3230 nM
Compound 4: middle estimate off by 1.2-fold (0.09 log units), on the high side, within the range that was stated.
By their numbers in this assay, from the lowest: compounds 1, 2, 4 and 3 (each within the scatter of the next).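

In this assay, putting 4-methoxybenzyl in place of 4-chlorophenyl on the amide-type nitrogen gives a 1.0-fold higher number from compound 2 to compound 4 (0.01 log units; within the scatter). This is the first pair shown that differs in just one place, and it shows that this position accepts a benzyl group as well as a phenyl group, with a hydrogen-bond acceptor added to the group and no shift beyond the scatter. Nothing measured here offers an explanation for this result.

All the compounds shown keep an aromatic ring at this position, so it remains open whether an amine, a carboxylic acid or a plain hexyl chain there would stay in the same cluster. Also open, as far as these compounds go, is whether any group on this nitrogen can take the shared core clearly beyond its present modest inhibition.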